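The source may report more compounds than this note shows. Statements on the series, on what has been measured and on what is new or still open speak of the compounds shown alone.

Working notes on the series. Of the compounds shown here, two carry numbers so far. Compound 1, `O=C(NCc1ccc(CNS(=O)(=O)c2cccc(F)c2)cc1)c1cccnc1`, gives 1000 nM in an assay on MDA-MB-231 cells for displacement of a labelled ligand from C-X-C chemokine receptor type 4 (Homo sapiens), read by fluorescence and microscopy, with stated times of 10 min and 30 min; a higher number here means that more compound is needed for the effect, a lower number that less compound is needed. Compound 2, `COc1ccccc1C(=O)NCc1ccc(CNS(=O)(=O)c2cccc(Cl)c2)cc1`, gives 1000 nM in this assay, which puts compound 2 level with compound 1 at the digits shown, a gap that sits within the scatter of this kind of measurement. Among the measured compounds shown here, no step between measured compounds that differ in a single place is available, so no measured size of step stands behind what follows.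

Compound 3, `COc1ccccc1C(=O)NCc1ccc(CNS(=O)(=O)c2cccc(F)c2)cc1`, is the next member to be run in this assay. It is obtained from compound 2 by the following change: fluoro in place of chloro on an aromatic carbon. Both measured compounds already sit at the same reading, one with fluoro and one with chloro on that ring, so the expectation for the step is none beyond the scatter: no change at the digits printed from compound 2 to compound 3 (within the scatter). On that basis compound 3 is expected to give about 1000 nM in this assay, with a range from 500 nM to 2000 nM.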

Compound 3, effective concentration (reported as EC, without a stated level of effect): 1000 nM
For compound 3 middle estimate and measured number coincide at the digits printed, and the stated range covers the measured number.
By their numbers in this assay, from the lowest: compounds 1, 2 and 3 (each within the scatter of the next).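

With compound 2 and compound 3 differing in one place, fluoro in place of chloro on the aromatic carbon gives no change at the digits printed from compound 2 to compound 3 (within the scatter) in this assay, a single-place reading for this position that compound 1 and compound 2, which differ in two places, could not give. Compound 3 also supplies a single-place reading at the other end of the molecule, where 2-methoxyphenyl in place of pyridin-3-yl on the carbonyl carbon gives no change at the digits printed from compound 1 to compound 3 (within the scatter) in this assay. Nothing available bears on why either exchange gives this result.

The compounds shown cover only two halogens at the aromatic position and two aromatic groups on the carbonyl carbon. Going by these compounds, whether an amine or a carboxylic acid at the place of fluoro, or a longer chain on the carbonyl carbon, would move the reading remains open.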